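A Hydrazone Series Tested for Antiproliferative Activity

The source may report more compounds than this note shows. Statements on the series, on what has been measured and on what is new or still open speak of the compounds shown alone.

Compound 1 `O=C(NN=C(c1ccccn1)c1ccccn1)c1ccncc1` was examined in an ADME assay on cells (Homo sapiens) for antiproliferative activity, read by MTT assay (on this read-out higher numbers stand for weaker inhibition and lower numbers for stronger inhibition), where compound 1 gives 830 nM. Among the compounds with values here, of the two numbers measured so far, compound 1 has the lower one. Compound 2 `C/C(=N\NC(=O)c1ccc(N)cc1)c1cnccn1`, built on a different core, gives in this assay a value of 58800 nM, far above compound 1 and well beyond the usual scatter. Within the data shown here, no step between two measured compounds that differ in a single place has been recorded, so the weight of one exchange on the core of compound 1 is not yet known.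

Compound 3 `O=C(NN=C(c1ccccn1)c1ccccn1)c1ccc(Br)cc1` is the next compound to be measured in this assay. Compared with compound 1, it carries 4-bromophenyl in place of pyridin-4-yl on a carbonyl carbon. Without a comparable measured step to lean on, the step is expected to be small, within or close to the scatter, and if anything toward a higher number, as estimated by a 1.6-fold higher number from compound 1 to compound 3 (0.19 log units; within the scatter). Compound 3 is therefore expected to give about 1300 nM, with a range from 300 nM to 5500 nM.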

Compound 3, half-maximal inhibitory concentration: 300 nM
For compound 3 the middle estimate is 4.3-fold (0.64 log units) above the measured one, and the stated range covers the measured number.
By their numbers in this assay, from the lowest: compound 3; then compound 1; then compound 2.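

In this assay, within the data shown here, exchanging pyridin-4-yl for 4-bromophenyl on a carbonyl carbon gives a 2.8-fold lower number from compound 1 to compound 3 (0.44 log units; beyond the scatter) as the first single-place step on the core of compound 1. It shows that this position responds to the exchange and that the pyridin-4-yl ring, with its ring nitrogen and hydrogen-bond acceptor, is not required here for inhibition in this range, since the carbon-only ring with bromine gives the stronger inhibition. No measured evidence bears on the reason for this step.

The ring nitrogen leaves and the bromine enters in the same exchange, so the compounds shown cannot assign the step to either, and an unsubstituted phenyl would separate the two. Also open, going by these compounds, is how this position would respond to an amine or a carboxylic acid on the ring.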